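From Vinyl to 2-Phenylethenyl on a Shared Core

A few compounds are considered here, and "the series" means these few. Any claim that something is new, unique, unknown or untested is made for them only; others in the source may bear on it.

Of the compounds shown here, three have so far been tested in a functional assay on K562 cells (Homo sapiens) for inhibition, read by thymidine incorporation, with a stated time of 48 h, tested at 10 ug/mL; a higher number here means more inhibition at the concentration tested (going by the name of the read-out), a lower number less inhibition. Compound 1 `Clc1nc(C#Cc2ccccc2)c2ncn(Cc3ccccc3)c2n1` gives 100%. Compound 2 `C=Cc1ncnc2c1ncn2Cc1ccccc1` gives 100%, and compound 3 `C=Cc1ncnc2ncn(Cc3ccccc3)c12` gives 100%. At the digits shown the three values are level, so compound 2 sits neither above nor below its companions: its value matches that of compound 1, its nearest relative, and equally that of compound 3, with no change beyond the scatter in either direction. Every measured value lies at the top of the scale, which leaves no room for an upward step.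

Compound 4 `C(=C/c1ncnc2c1ncn2Cc1ccccc1)\c1ccccc1` is the next compound to be measured. It differs from compound 2 in a single place: 2-phenylethenyl in place of vinyl on an aromatic carbon. Going by the values given here, no pair of measured compounds shares this exact change, so no measured step shows its effect. Given that compound 1, compound 2 and compound 3 all reach the top of the scale, the expectation is for a step from compound 2 to compound 4 of a number 5 percentage points lower from compound 2 to compound 4 (within the scatter), that is, none beyond the scatter, or at most a small drop. The estimate for compound 4 in this assay is therefore 95%, with a range from 75% to 100%.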

Compound 4, a percentage reported as inhibition, at one concentration (the size of the read-out at that concentration, not a potency): 93%
Compound 4: middle estimate off by 2 percentage points, on the high side; the range from low to high includes it.
By their numbers in this assay, from the lowest: compounds 4, 1, 2 and 3 (each within the scatter of the next).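

In this assay, going by these compounds alone, the swap of vinyl for 2-phenylethenyl on this aromatic carbon gives the first step that can be read at this place, and it comes out as a number 7 percentage points lower from compound 2 to compound 4 (within the scatter) on a single change to the shared core. The position can therefore carry a group with an added six-membered aromatic ring of carbon only, in place of vinyl, with no change beyond the scatter in this read-out. No measurement shown here speaks to why the two compounds read alike.

The read-out comes from one concentration and compound 2 stands at the top of the scale, so this step does not compare potency, and a real difference between the two compounds could stay hidden at that concentration. Open too, as far as these compounds go, is whether an amine, a carboxylic acid or a longer chain on this same aromatic carbon would keep the inhibition at this level, or whether the step would then grow beyond the scatter.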